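Swapping Amino for Methoxy on Two Weak Protease Binders

This account rests on a few compounds, and the source may have more. Where it says the series, first, only, none or still open, it means among the compounds named here.

Compound 1, `N=C(N)c1cccc(CN2CC[C@H](NS(=O)(=O)c3ccc4ccncc4c3)C2=O)c1`, in an assay on isolated protein for binding affinity to serine protease 1 (Homo sapiens) (a higher number here means a weaker inhibitor, a lower number a stronger inhibitor), gives > 2900 nM, which is a limit of the assay rather than a number.
Compound 2, `N=C(N)c1cccc(CN2CC[C@H](NS(=O)(=O)c3ccc4ccc(N)nc4c3)C2=O)c1`, in this assay gives > 2900 nM, again a limit of the assay rather than a number.

Among the compounds with values here, compound 2 therefore stands at the edge of what this assay can report: no inhibition constant, only the limit, and the one other value shown sits at that same limit, as the limit of > 2900 nM in this assay, at which 2 of the 2 values shown sit, records. Within the data shown here, no step between two measured compounds is available, so nothing here shows how a change on this part of the shared core moves the inhibition constant.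

Compound 3, `COc1ccc2ccc(S(=O)(=O)N[C@H]3CCN(Cc4cccc(C(=N)N)c4)C3=O)cc2n1`, differs from compound 2 in one place: methoxy in place of amino on an aromatic carbon. With both known values at the limit, the step from compound 2 to compound 3 in this assay is expected to be small, none beyond the scatter, with the direction open. For compound 3 the expected inhibition constant is 5000 nM, in a range from 1500 nM to 20000 nM. This amounts to an expected step that the limit leaves unreadable from compound 2 to compound 3, with a reading that again ends at the limit the most likely outcome.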

Compound 3, inhibition constant: > 2900 nM
Compound 3 gave a limit, no number (the forecaster's own chance of this, stated with the estimate: 75%); the middle value is on the limit's open side.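

Compound 2 and compound 3 both end at a limit in this assay rather than at a number, and no step can be read between them for methoxy in place of amino. The compounds shown leave open how strongly each one actually binds the protease, and whether this swap changes the inhibition constant at all.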